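Adding a Fluoro to Compound 1: Cytotoxicity Expectation

A few compounds are considered here, and "the series" means these few. Any claim that something is new, unique, unknown or untested is made for them only; others in the source may bear on it.

Compound 1 `Cc1cc(NC(=O)Nc2ccccc2F)c2ccccc2n1` — > 25000 nM
Compound 2 `Cc1cc(NC(=O)Nc2ccc(O)cc2)c2ccccc2n1` — > 25000 nM

In an ADME assay on BJ cells (Homo sapiens) for cytotoxicity, with a stated time of 72 h (a higher number here means that more compound is needed for the effect, a lower number that less compound is needed), compound 1 gives > 25000 nM, which is a limit of the assay rather than a measured number. In this assay compound 2 gives > 25000 nM, likewise a limit. The step that the two limits leave unreadable from compound 1 to compound 2 cannot be read, since both ends sit at the limit of > 25000 nM in this assay, at which 2 of the 2 values shown sit. Compound 1 therefore stands at the same limit as every value shown here.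

Compound 3 `Cc1cc(NC(=O)Nc2ccc(F)cc2F)c2ccccc2n1` differs from compound 1 by fluoro in place of hydrogen on an aromatic carbon. Among the compounds with values here, no measured step matches this change, and the only measured step, a step that the two limits leave unreadable from compound 1 to compound 2, gives no size to lean on. With nothing pointing either way, compound 3 is expected to stay at the limit, so the estimate is 30000 nM, between 15000 nM and 60000 nM. This estimate means a step that the limit leaves unreadable from compound 1 to compound 3, expected to lie within the scatter, with the assay most likely again reporting only a limit.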

Compound 3, half-maximal effective concentration: 20000 nM
Estimate against measurement, compound 3: 1.5-fold (0.18 log units) above; the range from low to high includes it.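

Within the data shown here, compound 3 gives the first real number of this set in this assay: with a fluoro group on the aromatic carbon that is para to a large group and meta to a fluoro group, the compound no longer sits at the limit. Going by these compounds, this change gives an at least 1.2-fold lower number from compound 1 to compound 3 (0.09 log units; that floor lies within the scatter), and as that is only a floor, the true size of the step stays unknown and may lie within the scatter or beyond it. The other two compounds offer no number to compare with: the limit of > 25000 nM in this assay, at which 2 of the 3 values shown sit.

On these data alone, how far compound 1 really lies from compound 3 remains open. So does whether an amine or a carboxylic acid on this same aromatic carbon would also give a real number in this assay.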